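This account rests on a few compounds, and the source may have more. Where it says the series, first, only, none or still open, it means among the compounds named here.

Of the compounds shown here, three that share one core have been tested in an assay on isolated protein for inhibition of steroid 5-alpha-reductase (Rattus norvegicus); on this read-out higher numbers stand for weaker inhibition and lower numbers for stronger inhibition. Compound 1 `COc1ccccc1N1CCN(CCCOc2ccc(C(=O)Nc3ccccc3OCCCC(=O)O)cc2)CC1` gives 41000 nM. Compound 2 `COc1ccccc1N1CCN(CCC(Oc2ccc(C(=O)Nc3ccccc3OCCCC(=O)O)cc2)c2ccccc2)CC1`, which carries a phenyl in place of hydrogen on a saturated chain carbon bound to an oxygen on an aromatic ring and a saturated chain carbon, gives 1000 nM; the step is a 41-fold lower number from compound 1 to compound 2 (1.61 log units; beyond the scatter). Compound 3 `COc1ccccc1N1CCN(CCC(Oc2ccc(C(=O)Nc3ccccc3OCCCC(=O)O)cc2)c2cccc(C)c2)CC1` gives 360 nM, the lowest of the three numbers: the step is a 110-fold lower number from compound 1 to compound 3 (2.06 log units; beyond the scatter), and the smaller one is a 2.8-fold lower number from compound 2 to compound 3 (0.44 log units; beyond the scatter). A methyl on an aromatic carbon of that phenyl thus shifted the number by a modest amount.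

Compound 4 `COc1ccccc1N1CCN(CCC(Oc2ccc(C(=O)Nc3ccccc3OCCCC(=O)O)cc2)c2ccc(C)cc2)CC1` differs from compound 3 in one place: 4-methylphenyl in place of 3-methylphenyl on a saturated chain carbon bound to an oxygen on an aromatic ring and a saturated chain carbon. The two have the same atoms joined differently, so nothing is added and nothing removed. Within the data shown here, of the measured steps only a 2.8-fold lower number from compound 2 to compound 3 (0.44 log units; beyond the scatter) concerns this part of the molecule, and it was modest; no measured pair shows what happens when the methyl sits elsewhere on the ring. The expectation is therefore a step within or close to the scatter, with the direction uncertain, a 1.3-fold higher number from compound 3 to compound 4 (0.10 log units; within the scatter). Compound 4 is expected to give about 450 nM, with a range from 150 nM to 1300 nM.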

Compound 4, half-maximal inhibitory concentration: 67 nM
Beside the measured number, compound 4's estimate is 6.7-fold (0.83 log units) above it, and the stated range ends above it.
By their numbers in this assay, from the lowest: compound 4; then compound 3; then compound 2; then compound 1.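

In this assay the exchange of 3-methylphenyl for 4-methylphenyl gives a 5.4-fold lower number from compound 3 to compound 4 (0.73 log units; beyond the scatter) with no atom added or removed, so where the methyl sits on this phenyl matters as well as whether it is present. Measured against the plain phenyl, the methyl of compound 4 gives a 15-fold lower number from compound 2 to compound 4 (1.17 log units; beyond the scatter) as a large step, whereas the methyl of compound 3 gave only a modest one, and the full change on the saturated chain carbon now reaches a 610-fold lower number from compound 1 to compound 4 (2.79 log units; beyond the scatter) overall. Nothing available here accounts for the difference between the two methylphenyl groups.

The compounds shown leave open whether the methyl itself is needed at the place it holds in compound 4, or whether another group there, such as an ethyl, a methoxy or a chlorine, would push the number lower still or lose the gain. Among these compounds, they also leave open whether a second methyl on the same phenyl, added to the one in compound 4, would take the number further down.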